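This account rests on a few compounds, and the source may have more. Where it says the series, first, only, none or still open, it means among the compounds named here.

In a functional assay, read by spectrophotometry, with a stated time of 20 min (a higher number here means a weaker inhibitor, a lower number a stronger inhibitor), compound 1 `CC(=O)c1ccc(NC(=O)CN(C(=O)c2ccccc2)S(=O)(=O)c2ccc([N+](=O)[O-])cc2)cc1` gives 58000000 nM. For the measured compounds named here, compound 2 `CC(=O)c1ccc(NC(=O)C(CC(C)C)N(C(=O)c2ccccc2)S(=O)(=O)c2ccc([N+](=O)[O-])cc2)cc1` gives 8400000 nM in this assay, the lower of the two numbers, and it stands apart from its only neighbour: a 6.9-fold lower number from compound 1 to compound 2 (0.84 log units; beyond the scatter), a modest shift that came with an isobutyl replacing a hydrogen on the chain carbon bound to the amide-type nitrogen and the carbonyl carbon.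

Compound 3 `CCC(C)C(C(=O)Nc1ccc(C(C)=O)cc1)N(C(=O)c1ccccc1)S(=O)(=O)c1ccc([N+](=O)[O-])cc1` carries a different kind of change: sec-butyl in place of isobutyl on a saturated chain carbon bound to an amide-type nitrogen and a carbonyl carbon; the two have the same atoms, joined differently. Going by the values given here, no measured step exchanges one branched chain for another at this position. Among the compounds with values here, the single known step compares a bare carbon with a substituted one and does not show how the shape of the substituent itself matters. What leaves and what enters are alike in everything that is counted: no ring, no hydrogen-bond donors or acceptors, no charge. The expected step in this assay is therefore small, in neither direction beyond the scatter: a 1.1-fold lower number from compound 2 to compound 3 (0.02 log units; within the scatter). Compound 3 is estimated at 8000000 nM, with a range from 3000000 nM to 25000000 nM.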

Compound 3, half-maximal inhibitory concentration: 50000000 nM
Compound 3: middle estimate off by 6.3-fold (0.80 log units), on the low side; measured number above the stated range.
By their numbers in this assay, from the lowest: compound 2; then compounds 3 and 1 (each within the scatter of the next).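

Exchanging isobutyl for sec-butyl on the chain carbon keeps the same atoms but joins them differently, and it still brings a 6.0-fold higher number from compound 2 to compound 3 (0.77 log units; beyond the scatter) at this position, so how the chain is joined counts here and not only which atoms it holds. Sec-butyl in place of hydrogen gives a 1.2-fold lower number from compound 1 to compound 3 (0.06 log units; within the scatter) and thus no shift that stands out from the scatter, which means that the lower number seen with isobutyl does not come with every substituent on this carbon. Nothing measured here explains why these two chains part ways.

The three compounds leave open whether the lower number belongs to isobutyl alone or extends to related groups, such as a straight butyl chain, a longer isopentyl chain or a benzyl group on the same carbon. They also leave open whether a carboxylic acid or an amine at the end of such a chain would follow compound 2 or compound 3, and whether any such group could bring the number far below that of compound 2.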